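From Compound 2 to Compound 3: Adding a Chain

A few compounds are considered here, and "the series" means these few. Any claim that something is new, unique, unknown or untested is made for them only; others in the source may bear on it.

Measured in an ADME assay for permeability, using PAMPA, with a stated time of 4 h, at pH 7.4; a higher number here means that the compound crosses the layer faster, a lower number that the compound crosses the layer more slowly:
- compound 1 `NCCCCN(C[C@@H]1Cc2ncccc2CN1)[C@H]1CCCc2cccnc21`: 7 nm/s
- compound 2 `CN(C[C@H]1Cc2ncccc2CN1)[C@H]1CCCc2cccnc21`: 1300 nm/s

Of these two measured compounds, compound 2 stands highest at 1300 nm/s. Compound 1 lies far lower at 7 nm/s, a gap well beyond the scatter.

The next compound to be tested is compound 3 `CN(C)CCCCN(C[C@H]1Cc2ncccc2CN1)[C@H]1CCCc2cccnc21`. Its difference from compound 2 is 3-(dimethylamino)propyl in place of hydrogen on a saturated chain carbon bound to an amine nitrogen, with 3-(dimethylamino)propyl in place of hydrogen on a saturated chain carbon bound to an amine nitrogen. Going by the values given here, no measured step bears directly on this change, so the low value of compound 1 at 7 nm/s is the main guide. A large downward step in this assay, beyond the scatter, is expected, and the estimate is a 33-fold lower number from compound 2 to compound 3 (1.51 log units; beyond the scatter). Compound 3 is estimated at 40 nm/s, with an expected range from 7 nm/s to 250 nm/s.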

Compound 3, apparent permeability: 240 nm/s
Compound 3: middle estimate off by 6.0-fold (0.78 log units), on the low side; low and high end bracket the measured number.
By their numbers in this assay, from the lowest: compound 1; then compound 3; then compound 2.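

In this assay, going by these compounds alone, this is the first direct reading of the change at this position: 3-(dimethylamino)propyl in place of hydrogen on a saturated chain carbon bound to an amine nitrogen gives a 5.4-fold lower number from compound 2 to compound 3 (0.73 log units; beyond the scatter) as a modest step. Seen one bond further out, as methyl to 4-(dimethylamino)butyl, the change still leaves compound 3 at 240 nm/s in this assay and so shows that this chain need not bring the number down to the lowest value in the set. Nothing at hand explains why the number falls with this change.

The compounds shown leave open whether the step follows the length of the chain or the dimethylamino group at its end. A plain butyl chain, or a chain ending in a hydroxyl group or a morpholine, would separate the two.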